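This account rests on a few compounds, and the source may have more. Where it says the series, first, only, none or still open, it means among the compounds named here.

Of the compounds shown here, three built on one shared core have been measured so far. Compound 1 `Cc1cccnc1-c1cnc(C(=O)CCCCCCc2ccccc2)o1` gives 15 nM in an assay (Rattus norvegicus) for inhibition of Fatty-acid amide hydrolase 1 (Homo sapiens); on this read-out lower numbers stand for stronger inhibition and higher numbers for weaker inhibition. Compound 2 `Cc1cccc(-c2cnc(C(=O)CCCCCCc3ccccc3)o2)n1` gives 3.3 nM in this assay, which is a 4.5-fold lower number from compound 1 to compound 2 (0.66 log units; beyond the scatter). Compound 3 `NC(=O)c1cccc(-c2cnc(C(=O)CCCCCCc3ccccc3)o2)n1` gives 1 nM in this assay, the lowest number of the three and therefore the strongest inhibitor here: the gain is a 3.3-fold lower number from compound 2 to compound 3 (0.52 log units; beyond the scatter) and a 15-fold lower number from compound 1 to compound 3 (1.18 log units; beyond the scatter), both beyond the scatter.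

Compound 4 `O=C(CCCCCCc1ccccc1)c1ncc(-c2cc(=O)[nH]c(=O)[nH]2)o1` takes the next step from compound 3. The change is a group of 8 heavy atoms (4 carbon, 2 nitrogen, 2 oxygen; one six-membered aromatic ring with 2 hetero atoms) in place of a group of 9 heavy atoms (6 carbon, 2 nitrogen, 1 oxygen; one six-membered aromatic ring with 1 hetero atom), on an aromatic carbon.

Going by the values given here, only one measured step touches this part of the molecule: the exchange of carbamoyl for methyl, a 3.3-fold lower number from compound 2 to compound 3 (0.52 log units; beyond the scatter), which shows that a group with a hydrogen-bond donor and acceptor at this place is favourable. Among the compounds with values here, no measured pair tests exchanging the whole six-membered ring, so the expectation for compound 4 is uncertain. Since the entering group also carries hydrogen-bond donors and acceptors, compound 4 is expected to stay close to compound 3, with a slight loss, giving an estimated 4.0-fold higher number from compound 3 to compound 4 (0.60 log units; beyond the scatter). For compound 4 the estimated inhibition constant in this assay is 4 nM, within a range from 0.7 nM to 25 nM.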

Compound 4, inhibition constant: 12 nM
Compound 4: middle estimate off by 3.0-fold (0.48 log units), on the low side; the measured number falls inside the stated range.
By their numbers in this assay, from the lowest: compound 3; then compound 2; then compounds 4 and 1 (each within the scatter of the next).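

In this assay, the exchange of 6-carbamoylpyridin-2-yl for a six-membered aromatic ring with 2 hetero atoms and two carbonyl groups outside its aromatic bonds is costly (a 12-fold higher number from compound 3 to compound 4 (1.08 log units; beyond the scatter)), so having hydrogen-bond donors and acceptors on this aromatic carbon does not by itself preserve the low number, something the earlier carbamoyl-for-methyl step could not show because it kept the pyridine ring. The new ring also gives a higher number than 6-methylpyridin-2-yl (a 3.6-fold higher number from compound 2 to compound 4 (0.56 log units; beyond the scatter)), even though methyl has no hydrogen-bond donor, while it cannot be told apart from 3-methylpyridin-2-yl (a 1.3-fold lower number from compound 1 to compound 4 (0.10 log units; within the scatter)). No measurement available here explains why this ring exchange costs so much.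

The compounds shown leave open whether the ring itself or the groups it carries set the result, a question that a pyridine ring bearing a carboxylic acid or an amine in place of carbamoyl could help to separate. Going by these compounds, it also remains open whether the same ranking of these groups would hold with a shorter chain in place of the present one.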